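Swapping a pyrazole for a fluorinated benzamide on a shared core

This account rests on a few compounds, and the source may have more. Where it says the series, first, only, none or still open, it means among the compounds named here.

Measured so far:
compound 1 `CC(c1cc2cccnc2cc1F)n1cnc2ncc(-c3cnn(CCO)c3)nc21` — 175 nM
compound 2 `CCC(c1cc2cccnc2cc1F)n1cnc2ncc(-c3cnn(CCO)c3)nc21` — "not determined" (no result reported)

Among the measured compounds shown here, compound 1 is the only compound of this set with a number in a functional assay on NCI-H1993 cells (Homo sapiens) for inhibition, read by CCK-8 assay, with a stated time of 72 h (a higher number here means a weaker inhibitor, a lower number a stronger inhibitor), where compound 1 gives 175 nM. Compound 2 shares the same core but carries a longer alkyl branch at the carbon joining the fused bicyclic group; in this assay compound 2 gives "not determined" (no result reported), so it offers no comparison. For the measured compounds named here, with only one number, compound 1 stands alone, neither strong nor weak relative to anything else in the set.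

The step to compound 3 `CNC(=O)c1ccc(-c2cnc3ncn(C(C)c4cc5cccnc5cc4F)c3n2)cc1F` involves one change on the core of compound 1: 3-fluoro-4-(methylcarbamoyl)phenyl in place of 1-(2-hydroxyethyl)-1H-pyrazol-4-yl on an aromatic carbon. The new group is larger and brings a carbonyl and an amide hydrogen in place of the hydroxyethyl chain. Going by the values given here, no step between measured compounds is available to guide the size of this effect. The expectation for compound 3 is therefore a step of a 1.5-fold lower number from compound 1 to compound 3 (0.16 log units; within the scatter), within the usual scatter, and in this assay compound 3 is estimated at 120 nM, with a range from 40 nM to 400 nM.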

Compound 3, half-maximal inhibitory concentration: 32.7 nM
Compound 3: middle estimate off by 3.7-fold (0.56 log units), on the high side; measured number below the stated range.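

In this assay, placing 3-fluoro-4-(methylcarbamoyl)phenyl where compound 1 carries 1-(2-hydroxyethyl)-1H-pyrazol-4-yl gives a 5.4-fold lower number from compound 1 to compound 3 (0.73 log units; beyond the scatter), a step beyond the scatter, and so shows that the number responds to the group on this aromatic carbon, which compound 1 and compound 2 share and therefore could not show. The change also shows that this position accepts a group with more heavy atoms, a six-membered aromatic ring of carbon only in place of a five-membered aromatic ring with 2 hetero atoms, without any loss in this assay, while the count of hydrogen-bond donors stays the same. No measurement here bears on why the number falls, and ring, chain and fluorine all change in this single step, so the step cannot be assigned to any one of them.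

On these data alone, whether the fluorine or the methylcarbamoyl group accounts for the step stays open, as does how a carboxylic acid or a primary amide in place of the methylcarbamoyl group would read in this assay. The step to compound 2 cannot be read, which leaves the effect of the longer alkyl branch open as well.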